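This account rests on a few compounds, and the source may have more. Where it says the series, first, only, none or still open, it means among the compounds named here.

Measured so far, in an ADME assay on CCRF-CEM cells (Homo sapiens) for cytotoxicity, with a stated time of 5 days; a higher number here means a weaker inhibitor, a lower number a stronger inhibitor:
compound 1 `O=C(/C=C/c1ccc(N2CCCCC2)cc1)c1ccc(Br)s1` gives 52800 nM;
compound 2 `O=C(/C=C/c1ccc(N2CCCCC2)cc1)c1ccc(I)s1` gives 22000 nM;
compound 3 `Brc1ccc(C2=NNC(c3ccc(N4CCCCC4)cc3)C2)s1` gives 21500 nM.

Compound 1 and compound 2 share one core and differ only by iodo in place of bromo on an aromatic carbon. That single change gave a 2.4-fold lower number from compound 1 to compound 2 (0.38 log units; beyond the scatter). Compound 3 has a different core from compound 1; the difference between the two cores is not broken down here. Compound 4 `Ic1ccc(C2=NNC(c3ccc(N4CCCCC4)cc3)C2)s1` is built on the core of compound 3 and differs from it by iodo in place of bromo on an aromatic carbon, the same change as before, at the same kind of place on the ring.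

Among the compounds with values here, for compound 4 in this assay a step of a 2.3-fold lower number from compound 3 to compound 4 (0.35 log units; beyond the scatter) is expected, resting on the one earlier example, because a 2.4-fold lower number from compound 1 to compound 2 (0.38 log units; beyond the scatter). Compound 4 is therefore estimated at 9500 nM, with a likely range from 4500 nM to 20000 nM.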

Compound 4, half-maximal inhibitory concentration: 36500 nM
For compound 4 the middle estimate is 3.8-fold (0.58 log units) below the measured one, outside the stated range (above it).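

In this assay the change from 5-bromothiophen-2-yl to 5-iodothiophen-2-yl on the core of compound 3 gave a 1.7-fold higher number from compound 3 to compound 4 (0.23 log units; within the scatter) and so cannot be told apart from the ordinary spread of repeat measurements. The same change did not carry over from one core to the other, since the two steps disagree by more than the scatter allows: the same change on two cores in this assay, a 2.4-fold lower number (0.38 log units; beyond the scatter) from compound 1 to compound 2 and a 1.7-fold higher number (0.23 log units; within the scatter) from compound 3 to compound 4, 4.1-fold (0.61 log units) apart, beyond the scatter of two such steps. Within the data shown here, this shows that a step seen on one core cannot simply be assumed on another, but with only one pair per core it does not explain the disagreement or give a rule for further cores.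

The compounds shown leave open how a different group at this place, such as chloro or an amine, would behave on each core. They also leave open which step, if either, a third core would follow.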